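Moving the nitro group on the benzyl arm

The source may hold more compounds than are shown below. What is called first, only, known or untested is meant among the compounds shown, and "the series" means these compounds.

Compound 1, `Cc1cc(C)c(Oc2cc(Nc3ccc(C#N)cc3)ncc2C(=O)NCc2cn(Cc3ccccc3C#N)nn2)c(C)c1`, gives > 219000 nM in an ADME assay on MT4 cells (Homo sapiens) for cytotoxicity, read by MTT assay, with a stated time of 5 days; a higher number here means that more compound is tolerated, a lower number that less compound is tolerated; this is a limit of the assay, not a number.
Compound 2, `Cc1cc(C)c(Oc2cc(Nc3ccc(C#N)cc3)ncc2C(=O)NCc2cn(Cc3ccc([N+](=O)[O-])cc3)nn2)c(C)c1`, gives >= 139000 nM in this assay; this too is a limit, not a number.

Compound 2 therefore stands at the limit of >= 139000 nM in this assay, at which 1 of the 2 values shown sits. Compound 1 stands at the limit of > 219000 nM in this assay, at which 1 of the 2 values shown sits. Because both values are limits, the step from compound 1 to compound 2, a step that the two limits leave unreadable from compound 1 to compound 2, cannot be read in size or direction; it only says that neither compound showed measurable cytotoxicity within the tested range.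

Compound 3, `Cc1cc(C)c(Oc2cc(Nc3ccc(C#N)cc3)ncc2C(=O)NCc2cn(Cc3cccc([N+](=O)[O-])c3)nn2)c(C)c1`, has not yet been measured. It differs from compound 2 by 3-nitrophenyl in place of 4-nitrophenyl on a saturated chain carbon bound to an aromatic nitrogen. Among the compounds with values here, no measured step touches a change of this kind, and the one measured step available is unreadable, so there is no basis for expecting a shift beyond the scatter in this assay in either direction. The most that can be said is that compound 2 and compound 1 both reached the assay limit, so compound 3 is expected to do the same. On that basis compound 3 is estimated at 150000 nM, between 60000 nM and 300000 nM. The step from compound 2 to compound 3 is thus expected to be a step that the limit leaves unreadable from compound 2 to compound 3, most likely reported again only as a limit.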

Compound 3, half-maximal cytotoxic concentration: >= 156000 nM
Compound 3: only a limit was reported; the forecaster's own chance of this, stated with the estimate: 80%; middle value at least 1.0-fold (0.01 log units) from the limit.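

Compound 3 is reported only as a limit, as are compound 1 and compound 2, so the steps from compound 1 and compound 2 to compound 3 cannot be read in size or direction. The compounds shown leave open whether 3-nitrophenyl, 4-nitrophenyl and 2-cyanophenyl differ at all in this assay.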